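Solubility notes on the pyrazole acylsulfonamide series

The compounds below may be only part of what the source reports. "The series", "measured", "known", "first", "only" and "open" are said of these compounds alone.

Measured compounds:
compound 1 `CS(=O)(=O)NC(=O)CCc1cn(-c2cccc(Br)c2)nc1-c1ccc(Cl)cc1`: < 5000 nM
compound 2 `CS(=O)(=O)NC(=O)CCc1cn(-c2ccc(Br)cc2)nc1-c1cccc(Cl)c1`: 165000 nM

In a physicochemical assay for solubility, in phosphate buffer, measured as thermodynamic solubility, at pH 7.4 (on this read-out lower numbers stand for lower solubility and higher numbers for higher solubility), compound 2 gives 165000 nM. Within the data shown here, this is the only plain number in the set. For compound 1 the read-out is a limit of the assay, < 5000 nM, and not a number; (the limit of < 5000 nM in this assay, at which 1 of the 2 values shown sits).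

Compound 3 `CS(=O)(=O)NC(=O)CCc1cn(-c2ccc(Br)cc2)nc1-c1ccc(N)cc1` differs from compound 2 in one place: 4-aminophenyl in place of 3-chlorophenyl on an aromatic carbon. Among the measured compounds shown here, no measured pair in the set differs in one place, so no step size is known for a change of this kind.

The step from compound 2 to compound 3 is expected to raise solubility, a 2.4-fold higher number from compound 2 to compound 3 (0.38 log units; beyond the scatter). Compound 3 is estimated at 400000 nM, with the likely range from 120000 nM to 1300000 nM.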

Compound 3, solubility: 160000 nM
Beside the measured number, compound 3's estimate is 2.5-fold (0.40 log units) above it; low and high end bracket the measured number.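

Among these compounds, at this position, on the aromatic carbon next to the ring nitrogen, 4-aminophenyl in place of 3-chlorophenyl gives the first readable step in this assay, with a 1.0-fold lower number from compound 2 to compound 3 (0.01 log units; within the scatter) as its size. With the 4-bromophenyl group and the 2-((methylsulfonyl)carbamoyl)ethyl group held fixed, this exchange of the chlorine for a nitrogen-bearing ring leaves the two values within the scatter of each other. Nothing measured here accounts for this step.

Among the compounds shown here, compound 1, at < 5000 nM, is a limit of the assay and differs from the other compounds in more than one place, so no step to it can be read. Open, on these data alone, is whether the same holds at this position for 3-aminophenyl, which would separate the placing of the amine from the exchange itself, or for a ring bearing a carboxylic acid.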